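Fluoro in place of nitro: expectation for compound 4

The source may report more compounds than this note shows. Statements on the series, on what has been measured and on what is new or still open speak of the compounds shown alone.

Compound 1 `CCOC(=O)C1=Cc2ccccc2OC1(OCc1cc(-c2ccc3ccccc3c2)no1)C(F)(F)F` carries a naphthalen-2-yl group, and in a functional assay on DU-145 cells (Homo sapiens) for inhibition, read by MTT assay, with a stated time of 24 h (on this read-out lower numbers stand for stronger inhibition and higher numbers for weaker inhibition), compound 1 gives 71800 nM. Compound 2 `CCOC(=O)C1=Cc2ccccc2OC1(OCc1cc(-c2ccc(Br)cc2)no1)C(F)(F)F` carries 4-bromophenyl instead, and in this assay compound 2 gives 71700 nM; the pair shows a 1.0-fold lower number from compound 1 to compound 2 (0.00 log units; within the scatter). Compound 3 `CCOC(=O)C1=Cc2ccccc2OC1(OCc1cc(-c2ccc([N+](=O)[O-])cc2)no1)C(F)(F)F` carries 4-nitrophenyl. In this assay compound 3 reaches only a limit, > 150000 nM, as recorded by the limit of > 150000 nM in this assay, at which 1 of the 3 values shown sits. Against the other two, compound 3 stands weakest: an at least 2.0-fold higher number from compound 1 to compound 3 (0.31 log units; beyond the scatter) and an at least 2.0-fold higher number from compound 2 to compound 3 (0.32 log units; beyond the scatter).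

Compound 4 `CCOC(=O)C1=Cc2ccccc2OC1(OCc1cc(-c2ccc(F)cc2)no1)C(F)(F)F` differs from compound 3 by fluoro in place of nitro on an aromatic carbon. The step that bears most directly on it is the bromo-to-nitro change, an at least 2.0-fold higher number from compound 2 to compound 3 (0.32 log units; beyond the scatter), which compound 4 reverses in kind by putting a halogen back on the ring. Since the naphthalen-2-yl and 4-bromophenyl compounds sit together, a 1.0-fold lower number from compound 1 to compound 2 (0.00 log units; within the scatter), a halogen-bearing ring is expected to land near compound 2. Compound 4 is therefore expected to improve on compound 3 by an at least 1.6-fold lower number from compound 3 to compound 4 (0.22 log units; that floor lies within the scatter), with the caveat that compound 3 is only a limit. The estimate for compound 4 in this assay is 90000 nM, from 40000 nM to 200000 nM.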

Compound 4, half-maximal inhibitory concentration: 53500 nM
The estimate for compound 4 lay 1.7-fold (0.23 log units) above the measured number; measured number inside the range.
By their numbers in this assay, from the lowest: compounds 4, 2 and 1 (each within the scatter of the next). At a limit, above all of these: compound 3.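

In this assay, fluoro in place of nitro on the carbon para to a large group gives an at least 2.8-fold lower number from compound 3 to compound 4 (0.44 log units; beyond the scatter), so a second halogen now parts from nitro at this position. Fluoro also reads with the larger groups, a 1.3-fold lower number from compound 2 to compound 4 (0.13 log units; within the scatter) and a 1.3-fold lower number from compound 1 to compound 4 (0.13 log units; within the scatter), so among the compounds shown only 4-nitrophenyl stands apart, while 4-fluorophenyl, 4-bromophenyl and naphthalen-2-yl cannot be told apart. Compound 3 remains a limit, so the full length of its step stays unknown: the limit of > 150000 nM in this assay, at which 1 of the 4 values shown sits.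

On these data alone, what separates nitro from the other three groups remains open. Also open, as far as these compounds go, is whether an amine or a carboxylic acid at this position would read with the halogens or with nitro.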